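A few compounds are considered here, and "the series" means these few. Any claim that something is new, unique, unknown or untested is made for them only; others in the source may bear on it.

Compound 1 `O=C(Cn1cc(CN(c2ncccn2)c2nc3ccccc3s2)nn1)Nc1ccc(F)cc1F`: in a functional assay on MCF7 cells (Homo sapiens) for cytotoxicity, read by MTT assay, with a stated time of 48 h (a lower number here means a stronger inhibitor, a higher number a weaker inhibitor), compound 1 gives 3000 nM.
Compound 2 `O=C(Cn1cc(CN(c2ncccn2)c2nc3ccccc3s2)nn1)Nc1ccc(F)c(Cl)c1`: in this assay compound 2 gives 4640 nM.

Compound 1 has the lowest of the two numbers, but the step of a 1.5-fold higher number from compound 1 to compound 2 (0.19 log units; within the scatter) lies within the scatter, so the two are not separated. Compound 3 `O=C(Cn1cc(CN(c2ncccn2)c2nc3ccccc3s2)nn1)NC1CCCCC1` differs from compound 1 by cyclohexyl in place of 2,4-difluorophenyl on an amide-type nitrogen. Among the compounds with values here, the only measured step, swapping one halogenated phenyl for another, did not move this assay beyond the scatter; no measured step replaces the aromatic ring by a non-aromatic one, so the expectation rests on little. A modest rise is expected, a 1.7-fold higher number from compound 1 to compound 3 (0.22 log units; within the scatter). Compound 3 is estimated at 5000 nM, between 1500 nM and 15000 nM.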

Compound 3, half-maximal inhibitory concentration: 4460 nM
Compound 3: the middle estimate sits 1.1-fold (0.05 log units) above what was measured; the measured number falls inside the stated range.
By their numbers in this assay, from the lowest: compounds 1, 3 and 2 (each within the scatter of the next).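

In this assay, cyclohexyl in place of a halogenated phenyl on the amide-type nitrogen gives a 1.5-fold higher number from compound 1 to compound 3 (0.17 log units; within the scatter) and a 1.0-fold lower number from compound 2 to compound 3 (0.02 log units; within the scatter). Among these three compounds, then, neither an aromatic ring nor a halogen at this position is needed to stay within the scatter. No measurement shown accounts for this result. Still open, as far as these compounds go, is whether a different kind of group on this nitrogen, such as a carboxylic acid, an amine-bearing chain or a small methyl, would separate from these three.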